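Sulfonyl substituent swap on the piperidine carboxamide series

The source may report more compounds than this note shows. Statements on the series, on what has been measured and on what is new or still open speak of the compounds shown alone.

Within the data shown here, compound 1 `O=C([C@@H]1CCCN(S(=O)(=O)c2ccc(S(=O)(=O)N3CC[C@@H](O)C3)cc2)C1)N1CCC(F)(F)CC1` gives 210 nM in a functional assay on MIA PaCa-2 cells (Homo sapiens) for inhibition, read by MTT assay, with a stated time of 7 days (on this read-out lower numbers stand for stronger inhibition and higher numbers for weaker inhibition), the lowest of the three numbers so far. Compound 3 `CCN(CC)S(=O)(=O)c1ccc(S(=O)(=O)N2CCC[C@@H](C(=O)N3CCC(C(F)(F)F)CC3)C2)cc1` gives 320 nM, within the scatter of compound 1, while compound 2 `CCN(CC)S(=O)(=O)c1ccc(S(=O)(=O)N2CCC[C@@H](C(=O)NC3COC3)C2)cc1` gives 2340 nM, well beyond it. Among the measured compounds shown here, the only single-point step measured, a 7.3-fold lower number from compound 2 to compound 3 (0.86 log units; beyond the scatter), sits at the carbonyl and says nothing about the sulfonyl end of the molecule.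

Compound 4 `CC(C)CS(=O)(=O)c1ccc(S(=O)(=O)N2CCC[C@@H](C(=O)N3CCC(F)(F)CC3)C2)cc1` differs from compound 1 at that sulfonyl end: isobutyl in place of 3-hydroxypyrrolidin-1-yl on a sulfonyl sulfur. For the measured compounds named here, no measured pair isolates a change at this position. Compounds 2 and 3 carry a group on the sulfonyl sulfur unlike either the one that leaves or the one that enters, and they differ from compound 1 at the amide as well, so their values only show that compound 1 and compound 3 land within the scatter of each other despite two simultaneous changes. That offers weak support for tolerance at the sulfonyl sulfur, and no support for a large move in either direction.

The expectation for compound 4 is therefore a number near that of compound 1, with a 1.4-fold higher number from compound 1 to compound 4 (0.15 log units; within the scatter) anticipated to stay inside the usual scatter. Compound 4 is estimated at 300 nM, with a range from 100 nM to 900 nM.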

Compound 4, half-maximal inhibitory concentration: 80 nM
The estimate for compound 4 lay 3.8-fold (0.57 log units) above the measured number, and the stated range ends above it.
By their numbers in this assay, from the lowest: compound 4; then compounds 1 and 3 (each within the scatter of the next); then compound 2.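

In this assay, among these compounds, the step at the sulfonyl sulfur, a 2.6-fold lower number from compound 1 to compound 4 (0.42 log units; beyond the scatter), lies beyond the scatter, and it is the first single-point reading at this position: the group on that sulfur does shift the number, and the change does not merely pass unnoticed. The step removes the ring, the hydrogen-bond donor, the hydrogen-bond acceptor and the defined stereocentre of 3-hydroxypyrrolidin-1-yl together, and the isobutyl compound gives the lower number, so none of these features is required for activity on the core of compound 1. No measured evidence bears on what lies behind this step.

Since these features leave together, the pair cannot assign the step to any one of them; unsubstituted pyrrolidin-1-yl, which keeps the ring without the hydroxyl, or a straight n-butyl chain would begin to separate them. On these data alone, the step also rests on a single pair with one amide, so whether isobutyl on the sulfonyl sulfur gives a similar step alongside other amides remains open.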